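Carbamate-to-oxadiazolylmethyl switch on the ring nitrogen

The source may report more compounds than this note shows. Statements on the series, on what has been measured and on what is new or still open speak of the compounds shown alone.

Among the compounds with values here, compound 3 `CS(=O)(=O)c1cnc(O[C@H]2CC[C@H](OC3CCN(C(=O)C4(C(F)(F)F)CC4)CC3)CC2)cn1` gives 140% in a functional assay on isolated protein for agonist activity at Glucose-dependent insulinotropic receptor (Rattus norvegicus), read by HTRF and cAMP accumulation (a higher number here means a larger maximal response, a lower number a smaller maximal response), the highest of the three numbers so far; compound 1 `CC1(OC(=O)N2CCC(O[C@H]3CC[C@H](Oc4cnc(S(C)(=O)=O)cn4)CC3)CC2)CC1` gives 123% and compound 2 `C[C@H](CF)OC(=O)N1CCC(O[C@H]2CC[C@H](Oc3cnc(S(C)(=O)=O)cn3)CC2)CC1` gives 115%. Compound 4 `CC(F)Cc1nc(CN2CCC(O[C@H]3CC[C@H](Oc4cnc(S(C)(=O)=O)cn4)CC3)CC2)no1` carries the change ((5-(2-fluoropropyl)-1,2,4-oxadiazol-3-yl)methyl in place of (1-(trifluoromethyl)cyclopropyl)carbonyl on an amine nitrogen in a ring). The measured steps all alter the group on the carbonyl carbon while the carbonyl stays: a number 8 percentage points lower from compound 1 to compound 2 (within the scatter), a number 17 percentage points higher from compound 1 to compound 3 (beyond the scatter) and a number 25 percentage points higher from compound 2 to compound 3 (beyond the scatter). None of them removes the carbonyl itself, so they bear on compound 4 only indirectly; they show that the maximal response moves by modest amounts when the group on the ring nitrogen is exchanged, and that the largest number sits with compound 3. Within the data shown here, with a larger change and no direct precedent, a downward step back toward the level of compound 1 and compound 2 is expected, a number 25 percentage points lower from compound 3 to compound 4 (beyond the scatter), but with wide uncertainty. Compound 4 is estimated at 115%, expected between 85% and 145%.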

Compound 4, largest response reached (Emax), in percent of the reference or control that the assay uses: 114%
Compound 4: the middle estimate sits 1 percentage points above what was measured; measured number inside the range.
By their numbers in this assay, from the lowest: compounds 4, 2 and 1 (each within the scatter of the next); then compound 3.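

With the carbonyl gone from the amine nitrogen in a ring, the response in this assay stays high: the step of a number 1 percentage points lower from compound 2 to compound 4 (within the scatter) and the step of a number 9 percentage points lower from compound 1 to compound 4 (within the scatter) put the (5-(2-fluoropropyl)-1,2,4-oxadiazol-3-yl)methyl group level with the carbonyl-bearing groups of those compounds. A carbonyl on this nitrogen is therefore not required for a response of that size among these compounds, while the (1-(trifluoromethyl)cyclopropyl)carbonyl group keeps its lead, with a number 26 percentage points lower from compound 3 to compound 4 (beyond the scatter) as the step away from it. The data at hand offer no explanation for that gap.

Open, from the compounds shown here alone, is how much the 2-fluoropropyl chain contributes, and whether a plain propyl or a cyclopropyl group on the oxadiazole would give the same response. Also open, going by these compounds, is whether a longer chain in place of the methyl link would hold that response.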